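The source may hold more compounds than are shown below. What is called first, only, known or untested is meant among the compounds shown, and "the series" means these compounds.

Three compounds frame the series in a functional assay on HCT-116 cells (Homo sapiens) for cytotoxicity, read by MTT assay, with a stated time of 48 h, in the presence of a further agent that is not named here; a lower number here means that less compound is needed, a higher number that more compound is needed for the effect. Compound 1 (`CCCc1cc(NNC(=O)Nc2cc(Cl)nc(Cl)c2)nc2c1c(C)nn2C`) gives 72200 nM, compound 2 (`Cn1ncc2c(-c3ccc(F)cc3)cc(NNC(=O)Nc3cc(Cl)cc(Cl)c3)nc21`) gives 39100 nM and compound 3 (`Cc1ccc(NC(=O)NNc2cc(-c3ccc(F)cc3)c3cnn(C)c3n2)cc1Nc1nccc(-c2cccnc2)n1`) gives 39200 nM. All three values lie within the usual scatter of one another, so compound 2 cannot be ranked apart from compound 1 or compound 3. Among the measured compounds shown here, no pair of measured compounds differs in a single place, so no single change has a direct measure yet.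

Compound 4 (`Cn1ncc2c(-c3ccc(F)cc3)cc(NNC(=O)Nc3cc(Cl)nc(Cl)c3)nc21`) keeps the core of compound 2 and changes one group: 2,6-dichloropyridin-4-yl in place of 3,5-dichlorophenyl on an amide-type nitrogen. This puts 2,6-dichloropyridin-4-yl in place of 3,5-dichlorophenyl on an amide-type nitrogen. The same 2,6-dichloropyridin-4-yl group already appears on a different core in compound 1, at 72200 nM, and that value stays within the scatter of compound 2 at 39100 nM. No step beyond the scatter is therefore expected in this assay. The estimate for a 1.2-fold higher number from compound 2 to compound 4 (0.06 log units; within the scatter) is expected to stay within the scatter. For compound 4 the estimated value is 45000 nM, with an expected range of 20000 nM to 95000 nM.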

Compound 4, half-maximal effective concentration: 8210 nM
For compound 4 the middle estimate is 5.5-fold (0.74 log units) above the measured one; measured number outside the range, below it.
By their numbers in this assay, from the lowest: compound 4; then compounds 2, 3 and 1 (each within the scatter of the next).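

In this assay, among the compounds shown here, the change to 2,6-dichloropyridin-4-yl in place of 3,5-dichlorophenyl on the amide-type nitrogen gives a 4.8-fold lower number from compound 2 to compound 4 (0.68 log units; beyond the scatter) and is the first single change with a direct measure. With the core of compound 2 held constant and the heavy-atom count unchanged, one ring carbon exchanged for nitrogen is enough to move the number beyond the scatter, so this position responds to a change of a single ring atom. No available measurement accounts for the step.

Open, from the compounds shown here alone, is how a plain pyridin-4-yl or a 2,6-dimethylpyridin-4-yl group would read at this place, which would test whether the two chlorine atoms matter alongside the ring nitrogen. Also open, going by these compounds, is whether the same step holds on a core other than that of compound 2.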